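This account rests on a few compounds, and the source may have more. Where it says the series, first, only, none or still open, it means among the compounds named here.

Compound 1 `CCCC(=O)N1CC2CC(C1)N2` is the starting point of this account. In an assay on SH-EP1 cells for agonist activity at Neuronal acetylcholine receptor; alpha4/beta2 (Homo sapiens), read by FLIPR and calcium flux (on this read-out higher numbers stand for larger maximal responses and lower numbers for smaller maximal responses), compound 1 gives 120%, the highest of the three numbers shown, although the steps to the other two compounds do not leave the usual scatter. Compound 2 `O=C([C@H]1C[C@H]1F)N1CC2CC(C1)N2` gives 110% in this assay, and compound 3 `O=C([C@@H]1C[C@H]1F)N1CC2CC(C1)N2` gives 110%. The step of a number 10 percentage points lower from compound 1 to compound 2 (within the scatter) and the step of a number 10 percentage points lower from compound 1 to compound 3 (within the scatter) both carry the same change, and the step of no change at the digits printed from compound 2 to compound 3 (within the scatter) separates two compounds that differ only in how one stereocentre is drawn, as the fact that one of compounds 2 and 3 is drawn with a defined configuration and the other without, at the place where they differ records.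

Compound 4 `C[C@H]1C[C@@H]1C(=O)N1CC2CC(C1)N2` brings a further change at the same carbonyl carbon: 2-methylcyclopropyl in place of propyl on a carbonyl carbon. Within the data shown here, the steps that bear on this change are the two from compound 1 to the fluorinated cyclopropyl compounds, each of which stayed within the scatter, so a small carbon ring at this position has so far left the maximal response essentially where compound 1 put it. By that reasoning a step of at most the size seen in those two cases is expected, in no clear direction beyond the scatter, which is what a number 5 percentage points lower from compound 1 to compound 4 (within the scatter) means. For compound 4 the expected value in this assay is therefore 115%, with a range from 95% to 135%.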

Compound 4, largest response reached (Emax), in percent of the reference or control that the assay uses: 67%
For compound 4 the middle estimate is 48 percentage points above the measured one; measured number outside the range, below it.
By their numbers in this assay, from the lowest: compound 4; then compounds 2, 3 and 1 (each within the scatter of the next).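

Among these compounds, the position on the carbonyl carbon is not indifferent to a small carbon ring after all: in this assay the change from propyl to 2-methylcyclopropyl gives a number 53 percentage points lower from compound 1 to compound 4 (beyond the scatter) and so leaves the scatter, which no earlier step did. The ring alone does not set the response, since compounds 2 and 3 also carry a three-membered ring and stay within the scatter of compound 1, while exchanging their 2-fluorocyclopropyl for 2-methylcyclopropyl gives a number 43 percentage points lower from compound 3 to compound 4 (beyond the scatter) and also a number 43 percentage points lower from compound 2 to compound 4 (beyond the scatter) in the same assay. What is at hand offers no explanation for this loss of maximal response.

The compounds shown leave open whether the other configurations of the 2-methylcyclopropyl group would give a similar number or would differ from compound 4, a question that matters here as the two fluorinated compounds sit level with each other. They also leave open where an unsubstituted cyclopropyl, a 2-ethylcyclopropyl or a 2-hydroxymethylcyclopropyl group would fall on this read-out, and so whether the loss follows the carbon substituent on the ring or belongs to the methyl group alone.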